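Effect of a second chloro on compound 1

The compounds below may be only part of what the source reports. "The series", "measured", "known", "first", "only" and "open" are said of these compounds alone.

Measured in an assay on cell membranes for displacement of a labelled ligand from Neuronal acetylcholine receptor; alpha4/beta2 (Rattus norvegicus); a higher number here means a weaker inhibitor, a lower number a stronger inhibitor:
compound 1 `Clc1cccc(Nc2ccc(N3CC4CC(C3)N4)cn2)c1` gives 2.2 nM
compound 2 `Clc1cccc(Nc2cncc(N3CC4CC(C3)N4)c2)c1` gives 0.124 nM
compound 3 `c1ccc(Nc2cncc(N3CC4CC(C3)N4)c2)cc1` gives 0.0807 nM

Compound 1 stands highest of the three. Compounds 2 and 3 share a core that is not the core of compound 1; the difference between the two cores is not broken down here. Compound 3 and compound 2 differ by chloro in place of hydrogen on an aromatic carbon, and that change gave a 1.5-fold higher number from compound 3 to compound 2 (0.19 log units; within the scatter).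

Compound 4 `Clc1ccc(Nc2ccc(N3CC4CC(C3)N4)cn2)cc1Cl` has not been measured. It differs from compound 1 by chloro in place of hydrogen on an aromatic carbon. This is the same kind of change as from compound 3 to compound 2, but the place differs: here ortho to a chloro group and para to a large group, there meta to a large group. Resting on a 1.5-fold higher number from compound 3 to compound 2 (0.19 log units; within the scatter), the step from compound 1 to compound 4 in this assay is expected to be a 1.4-fold higher number from compound 1 to compound 4 (0.13 log units; within the scatter). Compound 4 is thus estimated at 3 nM, likely between 1 nM and 10 nM.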

Compound 4, inhibition constant: 2.3 nM
Beside the measured number, compound 4's estimate is 1.3-fold (0.12 log units) above it, within the range that was stated.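

In this assay, chloro in place of hydrogen on the ring of compound 1 gives a 1.0-fold higher number from compound 1 to compound 4 (0.02 log units; within the scatter). Set beside the earlier step, the change reads alike on the two cores: the same change on two cores in this assay, a 1.5-fold higher number (0.19 log units; within the scatter) from compound 3 to compound 2 and a 1.0-fold higher number (0.02 log units; within the scatter) from compound 1 to compound 4, 1.5-fold (0.17 log units) apart, within the scatter of two such steps. This rests on one pair per core, with the chloro in a different place in each pair, so it shows no dependence on the core for these two cases but does not show that the change would carry to other places or other cores.

The compounds shown leave open whether a group other than chloro on this ring, such as methoxy or a nitrile, would give a step beyond the scatter. They also leave open how far the difference between the two cores depends on the groups on that ring.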